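A longer indole chain in compound 3

A few compounds are considered here, and "the series" means these few. Any claim that something is new, unique, unknown or untested is made for them only; others in the source may bear on it.

Measured in an ADME assay on MRC5 cells (Homo sapiens) for cytotoxicity, read by neutral red uptake, with a stated time of 24 h; a lower number here means a stronger inhibitor, a higher number a weaker inhibitor:
Compound 1 `CCCCCCCCCCCC(=O)Oc1c(C(C)C)cc2c3c1OC(=O)[C@@]31CCCC(C)(C)[C@@H]1CC2`: > 1000000 nM (a limit)
Compound 2 `CC(C)c1cc2c3c(c1OC(=O)Cc1c[nH]c4ccccc14)OC(=O)[C@@]31CCCC(C)(C)[C@@H]1CC2`: 109000 nM

Within the data shown here, compound 2 holds the only actual number so far. Compound 1 stands at the limit of > 1000000 nM in this assay, at which 1 of the 2 values shown sits. Among the measured compounds shown here, the one measured step, an at least 9.1-fold lower number from compound 1 to compound 2 (0.96 log units; beyond the scatter), put 1H-indol-3-yl in place of decyl. Compound 3 `CC(C)c1cc2c3c(c1OC(=O)CCCc1c[nH]c4ccccc14)OC(=O)[C@@]31CCCC(C)(C)[C@@H]1CC2` changes the same place, on a saturated chain carbon bound to a carbonyl carbon: 2-(1H-indol-3-yl)ethyl in place of 1H-indol-3-yl on a saturated chain carbon bound to a carbonyl carbon. The indole stays, so only a small rise in the number, within the scatter, is expected, far short of the step from decyl. The expected change is a 1.4-fold higher number from compound 2 to compound 3 (0.14 log units; within the scatter). The estimate for compound 3 is 150000 nM, with an expected range from 50000 nM to 450000 nM.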

Compound 3, half-maximal inhibitory concentration: 54500 nM
Estimate against measurement, compound 3: 2.8-fold (0.44 log units) above; measured number inside the range.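

At this position, adding to the chain that carries the indole does not separate the two indole esters: a 2.0-fold lower number from compound 2 to compound 3 (0.30 log units; within the scatter), so 2-(1H-indol-3-yl)ethyl and 1H-indol-3-yl read alike. The longer indole chain also stands clear of the plain fatty chain, with an at least 18-fold lower number from compound 1 to compound 3 (1.26 log units; beyond the scatter), so the gap seen with the shorter indole chain holds for both. Compound 1 stands at a limit, not a number: the limit of > 1000000 nM in this assay, at which 1 of the 3 values shown sits.

The compounds shown leave open whether an even longer chain to the indole would move the number beyond the scatter. They also leave open how an amine or a carboxylic acid in place of the indole would read on the same chain.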